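The source may report more compounds than this note shows. Statements on the series, on what has been measured and on what is new or still open speak of the compounds shown alone.

In a functional assay on U-251 cells (Homo sapiens) for antiproliferative activity, read by MTT assay, with a stated time of 48 h (on this read-out lower numbers stand for stronger inhibition and higher numbers for weaker inhibition), two compounds sharing one core have been measured so far. Compound 1 `COc1cc(-c2cccc3nc(-c4cccc(F)c4)oc23)cc(OC)c1OC` gives 2900 nM, and compound 2 `COc1cc(-c2cccc3nc(-c4ccc5cc[nH]c5c4)oc23)cc(OC)c1OC` gives 300 nM, the lower of the two numbers. The next structure, compound 3 `COc1cc(-c2cccc3nc(-c4ccco4)oc23)cc(OC)c1OC`, keeps the shared core and changes one group: furan-2-yl in place of 1H-indol-6-yl on an aromatic carbon. In words, furan-2-yl takes the place of 1H-indol-6-yl. Among the measured compounds shown here, the only measured step at this place, a 9.7-fold lower number from compound 1 to compound 2 (0.99 log units; beyond the scatter), lies beyond the scatter and brought in the 1H-indol-6-yl that compound 3 gives up, so a step back towards a higher number is expected, of similar or somewhat smaller size. For the measured compounds named here, no furan-2-yl compound has been measured yet, so this expectation is loose. The expected change is a 6.7-fold higher number from compound 2 to compound 3 (0.82 log units; beyond the scatter). In this assay the estimated value for compound 3 is 2000 nM, with an expected range from 600 nM to 7000 nM.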

Compound 3, half-maximal inhibitory concentration: 10600 nM
Estimate against measurement, compound 3: 5.3-fold (0.72 log units) below; measured number outside the range, above it.
By their numbers in this assay, from the lowest: compound 2; then compound 1; then compound 3.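

In this assay, the group on this aromatic carbon, next to the ring nitrogen and next to the ring oxygen, turns out to span a wider range than the first two compounds showed, since furan-2-yl in place of 1H-indol-6-yl gives a 35-fold higher number from compound 2 to compound 3 (1.55 log units; beyond the scatter) and is a large step. Furan-2-yl also falls behind 3-fluorophenyl, with a 3.7-fold higher number from compound 1 to compound 3 (0.56 log units; beyond the scatter) as the modest step, which makes compound 3 the weakest of the three. Nothing available here explains this order of the groups.

From the compounds shown here alone, compound 3 loses the hydrogen-bond donor and the six-membered aromatic ring of 1H-indol-6-yl together, so the share of each in the large step stays open. Going by these compounds, how a non-aromatic group at this place, such as an amine or a short alkyl chain, would compare also remains open.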